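Bromo to chloro on the furan of compound 2

The source may report more compounds than this note shows. Statements on the series, on what has been measured and on what is new or still open speak of the compounds shown alone.

Measured in a functional assay on NCI-H1299 cells (Homo sapiens) for inhibition, with a stated time of 48 h, at 37 degrees C; a higher number here means a weaker inhibitor of growth, a lower number a stronger inhibitor of growth:
Compound 1 `Clc1ccc(-c2noc(-c3sccc3Cl)n2)nc1`: > 10000 nM
Compound 2 `Clc1ccc(-c2noc(-c3occc3Br)n2)nc1`: > 10000 nM
Not yet measured:
Compound 3 `Clc1ccc(-c2noc(-c3occc3Cl)n2)nc1`

Compound 2 stands at > 10000 nM, which is a limit of the assay and not a number. Compound 1 gives > 10000 nM, and that too is only a limit. What the series shows so far is the limit of > 10000 nM in this assay, at which 2 of the 2 values shown sit.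

Compound 3 keeps the shared core of compound 2 and changes one group: chloro in place of bromo on an aromatic carbon. In words, 3-bromofuran-2-yl becomes 3-chlorofuran-2-yl, with chloro in place of bromo on an aromatic carbon.

Within the data shown here, the only measured step that bears on this is a step that the two limits leave unreadable from compound 1 to compound 2. Among the measured compounds shown here, it gives no size to carry over, and no measured step covers this exchange of halogens directly. The expectation therefore rests on compound 2 because compound 2 gives > 10000 nM, and no step beyond the scatter is expected in this assay, in either direction. The expected step is a step that the limit leaves unreadable from compound 2 to compound 3. Compound 3 is expected at 12000 nM, with an estimated range of 5000 nM to 30000 nM.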

Compound 3, concentration for 50% growth inhibition: > 10000 nM
Compound 3: only a limit was reported (the forecaster's own chance of this, stated with the estimate: 80%); the middle value lies beyond the limit too.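

In this assay compound 3 gives > 10000 nM and this is a limit of the assay, not a number. Among these compounds, no step among compound 1, compound 2 and compound 3 can be read, and the series stands at one value: the limit of > 10000 nM in this assay, at which 3 of the 3 values shown sit. The compounds shown leave open how strongly any of the three inhibits growth, and whether exchanging bromo for chloro alters it.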